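Chloro for fluoro on the anilino ring of compound 3

The compounds below may be only part of what the source reports. "The series", "measured", "known", "first", "only" and "open" are said of these compounds alone.

The series shares one core: compound 1 `COC(=O)c1c(Nc2ccc(Cl)cc2)sc(C(=O)c2ccc(OC)cc2)c1C`, compound 2 `COc1ccc(C(=O)c2sc(Nc3ccc(C)cc3)c(C(=O)O)c2C)cc1` and compound 3 `COc1ccc(C(=O)c2sc(Nc3ccc(F)cc3)c(C(=O)O)c2C)cc1` differ in the substituent on the anilino ring and, for compound 1, in the ester in place of the acid. In a functional assay, with a stated time of 150 min, tested at 10 ug/mL (on this read-out higher numbers stand for a stronger effect at the one concentration tested and lower numbers for a weaker effect), compound 1 is reported as "not active" (no number reported), and compound 2 likewise as "not active" (no number reported), both without a number. In this assay compound 3 gives 0.98%. Among the compounds with values here, that is the only number in the set; it lies at the bottom of the scale, and the two entries without a number give no footing for comparing compound 3 against them. Within the data shown here, no step between two measured compounds is available, so no measured size of any change is known here.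

Compound 4 `COc1ccc(C(=O)c2sc(Nc3ccc(Cl)cc3)c(C(=O)O)c2C)cc1` is the next compound to be tested. Its difference from compound 3 is chloro in place of fluoro on an aromatic carbon. On the evidence of compound 3 alone, with its 0.98%, the expected step from compound 3 to compound 4 in this assay is a number 0 percentage points higher from compound 3 to compound 4 (within the scatter), which means no change beyond the usual scatter. Compound 4 is therefore estimated at 1% in this assay, with a range from -6% to 10%; a report of "not active" without a number would fit this expectation as well.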

Compound 4, a percentage reported as activity, at one concentration (the size of the read-out at that concentration, not a potency): "not active" (no number reported)
Nothing numeric was reported for compound 4; no gap can be computed for the estimate.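

Within the data shown here, compound 4 carries no number in this assay and compound 3 does, so no step between compound 3 and compound 4 can be read. The compounds shown leave open whether exchanging fluoro for chloro on the anilino ring, or acid for ester, changes this read-out at all. No supporting data bear on this result.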